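This account rests on a few compounds, and the source may have more. Where it says the series, first, only, none or still open, it means among the compounds named here.

In a functional assay on Vero cells (Chlorocebus sabaeus) for inhibition (on this read-out higher numbers stand for weaker inhibition and lower numbers for stronger inhibition), compound 1 `COc1cc(/C=C/C(=O)c2cccc(NC(=O)c3ccco3)c2)ccc1O` gives 3.11 ug/mL. Compound 2 `COc1cc(/C=C/C(=O)c2cccc(NC(=O)c3ccc(Cl)c(Cl)c3)c2)ccc1O` reads > 50 ug/mL. That reading is a limit of the assay and not a number, so compound 2 has no exact place on the scale. Compound 3 `COc1cc(/C=C/C(=O)c2cccc(NC(=O)c3ccccc3)c2)ccc1O` keeps the shared core and alters one group: phenyl in place of 3,4-dichlorophenyl on a carbonyl carbon. Within the data shown here, only one measured step bears on this, and it is large: an at least 16-fold higher number from compound 1 to compound 2 (1.20 log units; beyond the scatter), made at the same carbonyl carbon when 3,4-dichlorophenyl replaced furan-2-yl. Phenyl is not the furan-2-yl of compound 1, so only part of that step is expected to be undone, and compound 3 may still reach the limit. A move toward stronger inhibition is expected, with an estimated at least 5.0-fold lower number from compound 2 to compound 3 (0.69 log units; beyond the scatter). For compound 3 the expected value is 10 ug/mL, with an estimated range of 2.5 ug/mL to 45 ug/mL.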

Compound 3, half-maximal inhibitory concentration: 3.47 ug/mL
Estimate against measurement, compound 3: 2.9-fold (0.46 log units) above; the measured number falls inside the stated range.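

In this assay, the 3,4-dichlorophenyl group on this carbonyl carbon gives way to plain phenyl, and inhibition returns: an at least 14-fold lower number from compound 2 to compound 3 (1.15 log units; beyond the scatter). The reading of compound 2 is a limit and not a number, so this step has only a lower bound: the limit of > 50 ug/mL in this assay, at which 1 of the 3 values shown sits. Phenyl and furan-2-yl at the same place cannot be told apart, with a 1.1-fold higher number from compound 1 to compound 3 (0.05 log units; within the scatter), so among these three compounds the loss of inhibition goes with the two chlorine atoms and not with a six-membered aromatic ring as such.

On these data alone, whether one chlorine alone is enough for that loss remains open, since both are present or absent together here. Also open, as far as these compounds go, is how this position would respond to a group of another kind on the phenyl ring, such as an amine or a carboxylic acid, or to a cyclohexyl group in place of the ring.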